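The compounds below may be only part of what the source reports. "The series", "measured", "known", "first", "only" and "open" are said of these compounds alone.

Compound 1 `COCc1ncc2cnnc(S)n12` gives, in a functional assay for inhibition, with Homo sapiens as the target (on this read-out higher numbers stand for weaker inhibition and lower numbers for stronger inhibition), only the limit > 48000 nM. Compound 2 `C=CCSc1nncc2cnc(COC)n12` gives 79000 nM. Compound 3 `COCc1ncc2cnnc(NCCN(C)C)n12` gives only the limit > 48000 nM.

Going by the values given here, compound 2 thus holds the only number among the three; the other two values are limits, as the limit of > 48000 nM in this assay, at which 2 of the 3 values shown sit, records. The steps a step that the limit leaves unreadable from compound 1 to compound 2, a step that the two limits leave unreadable from compound 1 to compound 3 and a step that the limit leaves unreadable from compound 2 to compound 3 cannot be read for size. Compound 4 `C=CCSc1nncc2cnc(CCC)n12` differs from compound 2 by ethyl in place of methoxy on a saturated chain carbon bound to an aromatic carbon. Among the compounds with values here, no measured step touches this change, so the expectation rests on compound 2 alone, and a step of no change at the digits printed from compound 2 to compound 4 (within the scatter) is estimated, meaning none beyond the scatter. Compound 4 is therefore expected at 79000 nM in this assay, with a range from 25000 nM to 250000 nM.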

Compound 4, half-maximal inhibitory concentration: > 48000 nM
Compound 4 was reported as a limit; the forecaster's own chance of this, stated with the estimate: 40%; the middle value does not contradict the limit.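

Compound 4 gives only a limit, > 48000 nM, in this assay, so no new step can be read between compound 2 and compound 4: the limit of > 48000 nM in this assay, at which 3 of the 4 values shown sit. The compounds shown leave open whether ethyl in place of methoxy on a saturated chain carbon bound to an aromatic carbon changes inhibition at all.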